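Working notes: sulfonamide aryl exchange and tissue distribution

The source may report more compounds than this note shows. Statements on the series, on what has been measured and on what is new or still open speak of the compounds shown alone.

Measured so far:
Compound 1 `CNC(=O)c1c(-c2ccc(F)cc2)oc2cc(-n3nccc3-c3ccc(B(O)O)c(F)c3)c(C3CC3)cc12` — in an ADME assay on the whole organism (Rattus norvegicus) for pharmacokinetics, read by LC-MS, at a dose of 1 mg/kg by the intravenous route (on this read-out lower numbers stand for narrower distribution and higher numbers for wider distribution into tissues), compound 1 gives 1.3 L/kg.
Compound 2 `CNC(=O)c1c(-c2ccc(F)cc2)oc2cc(N(Cc3ccc(B(O)O)c(F)c3)S(C)(=O)=O)c(C3CC3)cc12` — in this assay compound 2 gives 1.4 L/kg.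

Within the data shown here, compound 2 and compound 1 sit within the usual scatter of each other on this read-out, so these two numbers set no order between them and show only a narrow band for the series so far. Among the measured compounds shown here, no pair of measured compounds differs in a single place, and no step is therefore known in this assay.

Compound 3 `CNC(=O)c1c(-c2ccc(F)cc2)oc2cc(N(c3ccc(B(O)O)c(Cl)c3)S(C)(=O)=O)c(C3CC3)cc12` has not been measured. It differs from compound 2 by a group of 10 heavy atoms (6 carbon, 1 boron, 2 oxygen, 1 chlorine; one six-membered aromatic ring of carbon only) in place of a group of 11 heavy atoms (7 carbon, 1 boron, 2 oxygen, 1 fluorine; one six-membered aromatic ring of carbon only), on a sulfonamide nitrogen. The two measured compounds, which already carry different substituents in this region, give numbers within the scatter of each other, and nothing in them points to a move in either direction. The expected step from compound 2 to compound 3 is a 1.1-fold lower number from compound 2 to compound 3 (0.03 log units; within the scatter), which is none beyond the scatter. Compound 3 is estimated at 1.3 L/kg, with a range from 0.7 L/kg to 2.6 L/kg.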

Compound 3, volume of distribution at steady state: 1.1 L/kg
Estimate against measurement, compound 3: 1.2-fold (0.07 log units) above, within the range that was stated.
By their numbers in this assay, from the lowest: compounds 3, 1 and 2 (each within the scatter of the next).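

Among these compounds, the sulfonamide nitrogen now has the first single-place step in this assay: the group of 10 heavy atoms (6 carbon, 1 boron, 2 oxygen, 1 chlorine) in place of the group of 11 heavy atoms (7 carbon, 1 boron, 2 oxygen, 1 fluorine) gives a 1.3-fold lower number from compound 2 to compound 3 (0.10 log units; within the scatter), so this exchange does not separate the two compounds on this read-out. The exchange replaces fluorine with chlorine and removes one carbon in a single step, and the step cannot be divided between these two parts. No measurement shown bears on why the step has this size.

Whether any group on a sulfonamide nitrogen can move the number beyond the scatter stays open, for instance a group carrying an amine or a carboxylic acid in place of the groups shown here. Also open is how each part of the exchange acts alone, as the compounds shown include no group that has chlorine with the 7 carbons or fluorine with the 6 carbons.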